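The source may report more compounds than this note shows. Statements on the series, on what has been measured and on what is new or still open speak of the compounds shown alone.

Of the compounds shown here, three sharing one core have been measured in an assay on membranes from HeLa cells for displacement of a labelled ligand from adenosine receptor A3 (Homo sapiens), read by scintillation counting, with a stated time of 180 min, tested at 1 uM; on this read-out lower numbers stand for less inhibition and higher numbers for more inhibition at the one concentration tested (going by the name of the read-out). Compound 1 `COC(=O)C1=C(C)NC(=O)NC1c1cccs1` gives 3%. For the measured compounds named here, compound 2 `CC1=C(C(=O)CC(C)C)C(c2cccs2)NC(=O)N1` gives 18% in this assay, and the step of a number 15 percentage points higher from compound 1 to compound 2 (beyond the scatter) is the only single-place step among the measured compounds. Compound 3 `CCN(CC)C(=O)C1=C(C)NC(=O)NC1c1ccco1` gives 19% in this assay; it stands highest of the three numbers, though its gap to compound 2 lies within the scatter and only its gap to compound 1 lies beyond it.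

Compound 4 `CCN(CC)C(=O)C1=C(C)NC(=O)NC1c1cccs1` is not yet measured. It differs from compound 3 in one place: thiophen-2-yl in place of furan-2-yl on a saturated ring carbon. The measured step from compound 1 to compound 2 concerns the group on the carbonyl carbon, not the aromatic ring, so it does not bear on this change. Compound 1 and compound 2 both carry thiophen-2-yl, but each differs from compound 3 in two places, so their numbers give no clean comparison. Compound 4 is therefore expected to show no change at the digits printed from compound 3 to compound 4 (within the scatter), a step not beyond the scatter. The estimate for compound 4 in this assay is 19%, within a range from 5% to 33%.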

Compound 4, a percentage reported as inhibition, at one concentration (the size of the read-out at that concentration, not a potency): 31%
Beside the measured number, compound 4's estimate is 12 percentage points below it; low and high end bracket the measured number.
By their numbers in this assay, from the lowest: compound 1; then compounds 2 and 3 (each within the scatter of the next); then compound 4.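

In this assay, exchanging one five-membered aromatic ring for another on this saturated ring carbon is not a neutral change: sulfur in place of oxygen gives a number 12 percentage points higher from compound 3 to compound 4 (beyond the scatter) even though the heavy-atom count stays the same. With thiophen-2-yl held constant, the group on the carbonyl carbon also matters, as diethylamino gives a number 13 percentage points higher from compound 2 to compound 4 (beyond the scatter) in place of isobutyl and a number 28 percentage points higher from compound 1 to compound 4 (beyond the scatter) in place of methoxy, leaving compound 4 the highest of the four. Nothing measured here offers a reason for these steps.

From the compounds shown here alone, whether thiophen-2-yl also beats furan-2-yl with methoxy or isobutyl on the carbonyl carbon stays open; this pair can be compared only with diethylamino there. A phenyl ring on the saturated ring carbon, or a longer chain on the amide nitrogen, has no number among the compounds shown.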